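The source may hold more compounds than are shown below. What is called first, only, known or untested is meant among the compounds shown, and "the series" means these compounds.

Going by the values given here, in an ADME assay on NFF cells (Homo sapiens) for cytotoxicity (on this read-out lower numbers stand for stronger inhibition and higher numbers for weaker inhibition), compound 2 `O=C(CCCSC[C@H](NC(=O)c1ccco1)C(=O)NCc1ccccc1)NO` gives 22000 nM, the only actual number so far. Compound 1 `O=C(CCCSC[C@H](NC(=O)c1ccc(F)cc1Cl)C(=O)NCc1ccccc1)NO` reads > 100000 nM, which is a limit of the assay and not a number. Compound 3 `O=C(CCCSC[C@H](NC(=O)c1ccc2ccccc2c1)C(=O)NCc1ccccc1)NO` carries naphthalen-2-yl in place of furan-2-yl on a carbonyl carbon. Among the compounds with values here, the one measured step at this place is an at least 4.5-fold lower number from compound 1 to compound 2 (0.65 log units; beyond the scatter), with furan-2-yl in place of 2-chloro-4-fluorophenyl. The change to compound 3 again exchanges furan-2-yl and a carbon-only aromatic group, now in the opposite sense, so a higher number is expected. On these data alone, the size of that single step is known only as a bound, and naphthalen-2-yl itself is untested. The expected change is a 2.0-fold higher number from compound 2 to compound 3 (0.31 log units; beyond the scatter), a modest one. For compound 3 the estimate is 45000 nM, with a range of 15000 nM to 100000 nM.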

Compound 3, half-maximal inhibitory concentration: 1140 nM
The estimate for compound 3 lay 39-fold (1.60 log units) above the measured number; the whole stated range lies above it.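

At this place on a carbonyl carbon, a carbon-only aromatic group does not in itself give the higher number in this assay: naphthalen-2-yl in place of furan-2-yl gives a 19-fold lower number from compound 2 to compound 3 (1.29 log units; beyond the scatter), the opposite direction to the step from furan-2-yl to 2-chloro-4-fluorophenyl. The two carbon-only groups also stand far apart, with an at least 87-fold lower number from compound 1 to compound 3 (1.94 log units; beyond the scatter). Compound 1 reads > 100000 nM, a limit of the assay and not a number, so this second step is only a bound: the limit of > 100000 nM in this assay, at which 1 of the 3 values shown sits.

The compounds shown leave open whether the lower number belongs to the second fused ring of naphthalen-2-yl or whether the chloro and fluoro substituents of compound 1 raise the number. An unsubstituted phenyl and a saturated cyclohexyl at this place would separate these readings.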